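The source may report more compounds than this note shows. Statements on the series, on what has been measured and on what is new or still open speak of the compounds shown alone.

Compound 1 `CCCc1nc(C)c2c(C)nn(CC(=O)O)c(=O)n12` carries a carboxymethyl group on its core. In a functional assay for inhibition, with Homo sapiens as the target (a higher number here means a weaker inhibitor, a lower number a stronger inhibitor), compound 1 gives only > 48000 nM, which is a limit of the assay and not a number. Compound 2 `C=CCn1nc(C)c2c(C)nc(CCC)n2c1=O` is the closest measured neighbour of the new compound; in this assay compound 2 gives 69000 nM; > 48000 nM (2 entries), as the several entries of compound 2 in this assay, 69000 nM; > 48000 nM (2 entries) shows. Compound 3 `C=C=Cn1nc(C)c2c(C)nc(CCC)n2c1=O` differs from compound 1 by propa-1,2-dien-1-yl in place of carboxymethyl on an aromatic nitrogen. No measured step links two of these compounds, so any shift is expected to be none beyond the scatter. The step that the limit leaves unreadable from compound 1 to compound 3 is expected to be essentially flat. For compound 3 an inhibitory concentration of 60000 nM is estimated, between 20000 nM and 200000 nM.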

Compound 3, half-maximal inhibitory concentration: > 48000 nM
Compound 3 ended at the assay's limit; the forecaster's own chance of this, stated with the estimate: 60%; the middle value does not contradict the limit.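

Among the compounds shown here, compound 1 and compound 3 both end at a limit of the assay and not at a number, so no step between them can be read. The compounds shown leave open whether propa-1,2-dien-1-yl in place of carboxymethyl on an aromatic nitrogen shifts inhibition at all in this assay.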